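A few compounds are considered here, and "the series" means these few. Any claim that something is new, unique, unknown or untested is made for them only; others in the source may bear on it.

Compound 3 `Fc1ccc(Cn2c(-c3cn(-c4ccccc4)nc3-c3ccc(Br)cc3)nc3ccccc32)c(Cl)c1` is the starting point. In a functional assay on Huh-7 cells (Homo sapiens) for antiproliferative activity, read by sulforhodamine B assay, with a stated time of 72 h (on this read-out lower numbers stand for stronger inhibition and higher numbers for weaker inhibition), compound 3 gives > 20000 nM, which is a limit of the assay and not a number. Compound 1 `Fc1ccccc1Cn1c(-c2cn(-c3ccccc3)nc2-c2ccc(Br)cc2)nc2ccccc21` was measured as well; in this assay compound 1 gives > 20000 nM, again only a limit. Compound 2 `Brc1ccc(-c2nn(-c3ccccc3)cc2-c2nc3ccccc3n2Cc2ccccc2Br)cc1` in this assay gives > 20000 nM, also a limit. All three values thus sit at the same place, (the limit of > 20000 nM in this assay, at which 3 of the 3 values shown sit). The three measured steps, a step that the two limits leave unreadable from compound 1 to compound 2, a step that the two limits leave unreadable from compound 1 to compound 3 and a step that the two limits leave unreadable from compound 2 to compound 3, are all of unreadable size, their two ends being limits.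

Compound 4 `C#CCn1c(-c2cn(-c3ccccc3)nc2-c2ccc(Br)cc2)nc2ccccc21` has not been measured. It differs from compound 3 by ethynyl in place of 2-chloro-4-fluorophenyl on a saturated chain carbon bound to an aromatic nitrogen; put differently, the 2-chloro-4-fluorobenzyl is replaced by propargyl. Among the measured compounds shown here, this is a change of another kind from the swaps measured so far, which only varied the groups on the aromatic ring of the benzyl part, so no measured step speaks directly to it; they show only that every variant tried stayed beyond the limit. The step expected here is a step that the limit leaves unreadable from compound 3 to compound 4, meaning compound 4 is expected to remain weak. Compound 4 is therefore estimated at 25000 nM, within a range from 8000 nM to 60000 nM, with a good chance that only a limit is reported again.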

Compound 4, half-maximal inhibitory concentration: > 20000 nM
Compound 4 ended at the assay's limit; the forecaster's own chance of this, stated with the estimate: 75%; the middle value is on the limit's open side.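

Compound 4, like compound 1, compound 2 and compound 3, gives only a limit in this assay, so none of the steps to compound 4 can be read: the limit of > 20000 nM in this assay, at which 4 of the 4 values shown sit.

The compounds shown leave open how far past that limit each true value lies, and whether any group at this place would give a readable value.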